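Removing One Chlorine: What Happens to Red Blood Cells

The source may report more compounds than this note shows. Statements on the series, on what has been measured and on what is new or still open speak of the compounds shown alone.

Measured so far:
- compound 2 `N=C(N)c1ccc(-c2ccc(-c3ccc(Cl)cc3)o2)o1` gives 14%
- compound 1 `COc1ccc(-c2ccc(-c3ccc(C(=N)N)o3)o2)cc1` gives "non-toxic" (no number reported)
- compound 3 `N=C(N)c1ccc(-c2ccc(-c3ccc(Cl)cc3)s2)s1` gives "non-toxic" (no number reported)

All three readings come from an ADME assay on cells (Erythrocyte, Homo sapiens) for activation, read by hemolysis, with a stated time of 30 min, tested at 1.25 mM; a lower number here means a weaker effect, a higher number a stronger effect of the compound at the concentration tested. For the measured compounds named here, compound 2 stands alone as the one compound with an actual number; compound 1 and compound 3 each come with only a word and no figure, so no numerical comparison among the three is possible, and no step between measured compounds can be worked out.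

Compound 4 `N=C(N)c1ccc(-c2ccc(-c3ccccc3)o2)o1` has not been tested yet. The difference from compound 2 is hydrogen in place of chloro on an aromatic carbon.

Going by the values given here, with no measured step to lean on, the only guide is that compound 2 itself shows a low reading in this assay. A change of a single heavy atom at the edge of the molecule is expected to move the reading little, most likely not beyond the scatter, or slightly downward. The step from compound 2 to compound 4 is therefore estimated at a number 4 percentage points lower from compound 2 to compound 4 (within the scatter). Compound 4 is expected to give 10%, within a range of 0% to 25%.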

Compound 4, a percentage reported as activity, at one concentration (the size of the read-out at that concentration, not a potency): "non-toxic" (no number reported)
Compound 4 has no reported number here; the estimate stays without a comparison.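

For the compounds shown here, compound 4 gives "non-toxic" (no number reported) in this assay, a word rather than a figure, so no step from compound 2 to compound 4 can be read. Going by these compounds, how much swapping chloro for hydrogen shifts the reading stays open. No supporting data bear on this result.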